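The compounds below may be only part of what the source reports. "The series", "measured", "known", "first", "only" and "open" are said of these compounds alone.

In an ADME assay on microsomes from liver (Homo sapiens) for metabolic stability, read by LC-MS, with a stated time of 30 min, tested at 1 uM (a higher number here means that more of the compound is left, a lower number that less of the compound is left), compound 1 `O=C(NCc1ccc(S(=O)(=O)c2cccc(C(F)(F)F)c2)cc1)c1cc2ccncc2o1` gives 48%. Compound 2 `O=C(NCc1ccc(S(=O)(=O)N2CCCCC2)cc1)c1cc2ccncc2o1` gives 56%, and compound 3 `O=C(NCc1ccc(S(=O)(=O)c2cc(F)cc(F)c2)cc1)c1cc2ccncc2o1` gives 77%. Compound 1 therefore sits within the scatter of compound 2, and both stand clearly under compound 3.

Compound 4 `O=C(NCc1ccc(S(=O)(=O)c2cccc(C(F)(F)F)c2)cc1)c1cc2ccncc2s1` differs from compound 1 in one place: a group of 9 heavy atoms (7 carbon, 1 nitrogen, 1 sulfur; one five-membered aromatic ring with 1 hetero atom, one six-membered aromatic ring with 1 hetero atom) in place of a group of 9 heavy atoms (7 carbon, 1 nitrogen, 1 oxygen; one five-membered aromatic ring with 1 hetero atom, one six-membered aromatic ring with 1 hetero atom), on a carbonyl carbon. In plain terms, sulfur takes the place of oxygen, and the ring counts stay the same.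

Going by the values given here, no measured step touches this group. All three change the group on a sulfonyl sulfur instead: a number 8 percentage points higher from compound 1 to compound 2 (within the scatter), a number 29 percentage points higher from compound 1 to compound 3 (beyond the scatter) and a number 21 percentage points higher from compound 2 to compound 3 (beyond the scatter). They bear on the question only indirectly, showing how far this assay can move when a single group is exchanged, and they give no direction for the new change. A step beyond the scatter is therefore not expected, though the uncertainty stays wide.

The estimate for compound 4 is 45%, with an expected range from 27% to 63%. This estimate means an expected a number 3 percentage points lower from compound 1 to compound 4 (within the scatter).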

Compound 4, percent of the compound remaining: 43%
For compound 4 the middle estimate is 2 percentage points above the measured one; the range from low to high includes it.
By their numbers in this assay, from the lowest: compounds 4, 1 and 2 (each within the scatter of the next, the first and the last beyond it); then compound 3.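

With the group on the sulfonyl sulfur held as 3-(trifluoromethyl)phenyl, putting sulfur in place of oxygen in the group on the carbonyl carbon gives, in this assay, a number 5 percentage points lower from compound 1 to compound 4 (within the scatter). Going by these compounds alone, this is the first view of a change at this second place in the molecule, and this exchange of one atom leaves the read-out within its usual spread, whereas a change on the sulfonyl sulfur gave a number 29 percentage points higher from compound 1 to compound 3 (beyond the scatter). Nothing measured here explains the result of this exchange.

From the compounds shown here alone, whether the same exchange would also leave the number in place with 3,5-difluorophenyl or piperidin-1-yl on the sulfonyl sulfur remains open. Also open, going by these compounds, is what a nitrogen carrying a hydrogen would do in place of the sulfur, or what a larger replacement of the whole group on the carbonyl carbon would do.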